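Thiourea analogue of the dimethylaminophenyl pair: expected activity

The source may report more compounds than this note shows. Statements on the series, on what has been measured and on what is new or still open speak of the compounds shown alone.

Working notes on three measured compounds and one still to be tested. Compound 1 `COc1cc(/C=C/C(=O)C2=C(/C=C/c3ccc(O)c(OC)c3)NC(=O)NC2c2ccccc2O)ccc1O` gives 80.9% in a functional assay, with a stated time of 20 min, tested at 20 uM; on this read-out lower numbers stand for a weaker effect and higher numbers for a stronger effect at the one concentration tested. Compound 2 `COc1cc(/C=C/C(=O)C2=C(/C=C/c3ccc(O)c(OC)c3)NC(=O)NC2c2ccc(N(C)C)cc2)ccc1O` gives 82.2% in this assay. The two differ by one change, (4-(dimethylamino)phenyl in place of 2-hydroxyphenyl on a saturated ring carbon), and the step of a number 1.3 percentage points higher from compound 1 to compound 2 (within the scatter) is within the scatter. Compound 3 `COc1cc(/C=C/C(=O)C2=C(/C=C/c3ccc(O)c(OC)c3)NC(=S)NC2c2ccccc2O)ccc1O` gives 79.9% in this assay; its value and those of compound 1 and compound 2 lie within the scatter of one another, so no order among the three is claimed. The difference between the core of compound 1 and the core of compound 3 is not broken down here.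

Compound 4 `COc1cc(/C=C/C(=O)C2=C(/C=C/c3ccc(O)c(OC)c3)NC(=S)NC2c2ccc(N(C)C)cc2)ccc1O` has not yet been measured. It differs from compound 3 by 4-(dimethylamino)phenyl in place of 2-hydroxyphenyl on a saturated ring carbon, which is the same change as that from compound 1 to compound 2, now made on the core of compound 3. Because the earlier step of a number 1.3 percentage points higher from compound 1 to compound 2 (within the scatter) stayed within the scatter, the step of a number 1.1 percentage points higher from compound 3 to compound 4 (within the scatter) is expected to stay within the scatter as well. Compound 4 is therefore estimated at 81% in this assay, expected between 72% and 89%.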

Compound 4, a percentage reported as activity, at one concentration (the size of the read-out at that concentration, not a potency): 72.1%
Estimate against measurement, compound 4: 8.9 percentage points above; the measured number falls inside the stated range.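

In this assay, 4-(dimethylamino)phenyl in place of 2-hydroxyphenyl on a saturated ring carbon of the core of compound 3 gives a number 7.8 percentage points lower from compound 3 to compound 4 (within the scatter). The step on this core cannot be told apart from the earlier step on the core of compound 1: the same change on two cores in this assay, a number 1.3 percentage points higher (within the scatter) from compound 1 to compound 2 and a number 7.8 percentage points lower (within the scatter) from compound 3 to compound 4, 9.1 percentage points apart, within the scatter of two such steps. This shows no dependence of the change on the core within the resolution of the assay, but it does not show that the two steps are equal, and a smaller dependence on the core could lie hidden in the scatter of these single-concentration read-outs, which are not potencies.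

The compounds shown leave open whether the same holds for other groups on that saturated ring carbon, such as plain phenyl, 4-methoxyphenyl, 4-carboxyphenyl or a short alkyl chain in place of the aromatic ring. They also leave open whether the two cores would separate at other concentrations, with a stronger or weaker effect on one core than on the other at those concentrations.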